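The source may hold more compounds than are shown below. What is called first, only, known or untested is meant among the compounds shown, and "the series" means these compounds.

In a functional assay on THP-1 cells (Homo sapiens) for inhibition, read by sulforhodamine B assay, with a stated time of 48 h, tested at 50 uM (on this read-out lower numbers stand for less inhibition of growth and higher numbers for more inhibition of growth at the one concentration tested), three compounds have been read so far. Compound 1 (`COc1cc(/C=C/C(=O)/C=C/c2cccc3ccccc23)ccc1OCc1cn(CCCOc2cc(=O)oc3ccccc23)nn1`) gives 71% and stands in the middle of them: compound 2 (`COc1cc(/C=C/C(=O)/C=C/c2cccc3ccccc23)ccc1OCc1cn(CCCCOc2cc(=O)oc3ccccc23)nn1`) gives a lower 54% and compound 3 (`COc1ccc(/C=C/C(=O)/C=C/c2ccc(OCc3cn(CCOc4cc(=O)oc5ccccc45)nn3)c(OC)c2)cc1OC`) a higher 90%, both gaps beyond the scatter. Compound 4 (`COc1cc(/C=C/C(=O)/C=C/c2ccccc2)ccc1OCc1cn(CCCOc2cc(=O)oc3ccccc23)nn1`) carries phenyl in place of naphthalen-1-yl on a double-bonded chain carbon bound to a double-bonded chain carbon. Among the measured compounds shown here, no measured pair shows a change made in one place, so only a small fall in this assay, not beyond the scatter, is expected. The estimated step is a number 6 percentage points lower from compound 1 to compound 4 (within the scatter). For compound 4 the expected value is 65%, with an estimated range of 45% to 85%.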

Compound 4, percent growth inhibition at one concentration: 48%
Compound 4: the middle estimate sits 17 percentage points above what was measured, and the stated range covers the measured number.
By their numbers in this assay, from the lowest: compounds 4 and 2 (each within the scatter of the next); then compound 1; then compound 3.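

Phenyl in place of naphthalen-1-yl on a double-bonded chain carbon bound to a double-bonded chain carbon gives a number 23 percentage points lower from compound 1 to compound 4 (beyond the scatter) in this assay and is the first change in one place to be read here. At this position, the naphthalen-1-yl of compound 1 therefore goes with more growth inhibition than the phenyl of compound 4, though this rests on a single pair. Nothing at hand explains the fall.

Going by these compounds, whether a naphthalen-2-yl or a pyridinyl group at this position would hold or lose the inhibition stays open. So does whether the step would be the same with a longer chain on the triazole nitrogen.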